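Aryl swap on the amide: compound 3 to compound 4

This account rests on a few compounds, and the source may have more. Where it says the series, first, only, none or still open, it means among the compounds named here.

Measured in a functional assay on HT-29 cells (Homo sapiens) for cytotoxicity, read by MTT assay, with a stated time of 72 h; on this read-out lower numbers stand for stronger inhibition and higher numbers for weaker inhibition:
compound 1 `Cc1ccc(NC(=O)CN2CCN(c3nnc(Cc4ccncc4)c4ccccc34)CC2)c(C)c1`: 1930 nM
compound 2 `COc1ccc(NC(=O)CN2CCN(c3nnc(Cc4ccccc4)c4ccccc34)CC2)cc1OC`: 145000 nM
compound 3 `O=C(CN1CCN(c2nnc(Cc3ccccc3)c3ccccc23)CC1)Nc1ccc(Br)cc1`: 60200 nM

Of these three numbers, compound 3 has the second highest. Next comes compound 4 `Cc1ccc(NC(=O)CN2CCN(c3nnc(Cc4ccccc4)c4ccccc34)CC2)c(C)c1`, with 2,4-dimethylphenyl in place of 4-bromophenyl on an amide-type nitrogen. Within the data shown here, the only measured step at this place is modest: a 2.4-fold lower number from compound 2 to compound 3 (0.38 log units; beyond the scatter). Compound 1 also carries 2,4-dimethylphenyl and gives 1930 nM, but it differs from compound 3 elsewhere too, so it gives no clean guide. A small move toward a lower number in this assay is expected, possibly not beyond the scatter. The expected step is a 1.5-fold lower number from compound 3 to compound 4 (0.18 log units; within the scatter). The estimate for compound 4 is 40000 nM, with an expected range of 12000 nM to 120000 nM.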

Compound 4, half-maximal inhibitory concentration: "not active" (no number reported)
Compound 4: no number reported, and the estimate cannot be compared.
By their numbers in this assay, from the lowest: compound 1; then compound 3; then compound 2.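

Among these compounds, compound 4 is reported as not active in this assay without a number, so no step from compound 3 to compound 4 can be read. From the compounds shown here alone, how 2,4-dimethylphenyl compares with 4-bromophenyl on the amide-type nitrogen stays open. No supporting data bear on this result.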